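Swapping the fluorines for a single chlorine on the phenyl

This account rests on a few compounds, and the source may have more. Where it says the series, first, only, none or still open, it means among the compounds named here.

Of the compounds shown here, three of one shared core have been measured in a functional assay on CHO cells with adenosine receptor A1 (Homo sapiens) as the target, read by cAMP accumulation and immunoassay, with a stated time of 6 min, tested at 0.1 uM; a lower number here means a stronger effect, a higher number a weaker effect of the compound at the concentration tested. Compound 1 `Nc1scc(CN2CCN(c3cccc(Cl)c3Cl)CC2)c1C(=O)c1ccc(Cl)cc1` gives 3.2%, compound 2 `Nc1scc(CN2CCN(c3ccc(F)cc3F)CC2)c1C(=O)c1ccc(Cl)cc1` gives -17%, and compound 3 `Nc1scc(CN2CCN(c3cc(F)ccc3F)CC2)c1C(=O)c1ccc(Cl)cc1` gives -13%. Compound 3 therefore stands second highest of the three numbers: its nearest neighbour is compound 2, whose number is four points lower, within the scatter, and its furthest is compound 1, whose number is higher by a margin beyond the scatter.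

The next compound, compound 4 `Nc1scc(CN2CCN(c3cccc(Cl)c3)CC2)c1C(=O)c1ccc(Cl)cc1`, differs from compound 3 in one place: 3-chlorophenyl in place of 2,5-difluorophenyl on an amine nitrogen in a ring.

For the measured compounds named here, two measured steps bear on this. Replacing the chlorine-bearing phenyl of compound 1 with a difluorophenyl gave a number 20.2 percentage points lower from compound 1 to compound 2 (beyond the scatter) and a number 16.2 percentage points lower from compound 1 to compound 3 (beyond the scatter), both modest but beyond the scatter, while the two difluorophenyls differ only by a number 4 percentage points higher from compound 2 to compound 3 (within the scatter). Returning to a chlorine-bearing phenyl, though with one chlorine rather than two, is expected to move the number back upward by a modest amount. The estimated step is a number 8 percentage points higher from compound 3 to compound 4 (within the scatter).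

Compound 4 is thus estimated to give -5% in this assay, within a range from -20% to 10%.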

Compound 4, a percentage reported as activity, at one concentration (the size of the read-out at that concentration, not a potency): -20%
Compound 4: the middle estimate sits 15 percentage points above what was measured, within the range that was stated.
By their numbers in this assay, from the lowest: compounds 4, 2 and 3 (each within the scatter of the next); then compound 1.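

In this assay, the 3-chlorophenyl of compound 4 cannot be told apart from either difluorophenyl, with a number 7 percentage points lower from compound 3 to compound 4 (within the scatter) and a number 3 percentage points lower from compound 2 to compound 4 (within the scatter), whereas the gap to the 2,3-dichlorophenyl is larger, with a number 23.2 percentage points lower from compound 1 to compound 4 (beyond the scatter). A chlorine on this phenyl therefore does not by itself bring the number back up: among these four compounds only compound 1 stands apart, and compound 4 differs from it by hydrogen in place of chloro on an aromatic carbon. No measurement shown here accounts for this difference.

Open, as far as these compounds go, is whether the higher number of compound 1 depends on that second chlorine specifically, or whether a methyl or methoxy group in its place would give a similar number. Also open, from the compounds shown here alone, is how a phenyl with no substituent at all, or a 3-methoxyphenyl or 3-methylphenyl on the same amine nitrogen, would compare with compound 4, which would show whether the single chlorine matters at all.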